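Methoxy to hydroxy on the methylphenyl ring of compound 3

The source may hold more compounds than are shown below. What is called first, only, known or untested is meant among the compounds shown, and "the series" means these compounds.

Measured so far:
compound 1 `COc1cc(C)cc(-c2c(-c3ccnc(-c4ccc(C(C)=O)cc4)c3)cnn2CC#N)c1`: 77%
compound 2 `Cc1cc(O)cc(-c2nn(CC#N)cc2-c2ccnc(-c3ccc(Oc4ccccc4)cc3)c2)c1`: 78%
compound 3 `COc1cc(C)cc(-c2nn(CC#N)cc2-c2ccnc(-c3ccc(N(C)C)cc3)c2)c1`: 88%

Read-out is a functional assay on A498 cells (Homo sapiens) for cytotoxicity, read by sulforhodamine B assay, with a stated time of 48 h, tested at 0.01 uM; on this read-out higher numbers stand for a weaker effect at the one concentration tested and lower numbers for a stronger effect. Of the three numbers, compound 3 holds the highest. Compound 2 sits within the scatter of compound 3, so no order between these two is claimed. Among the compounds with values here, compound 1 lies beyond the scatter below compound 3 and is the only number that separates from it.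

Compound 4 `Cc1cc(O)cc(-c2nn(CC#N)cc2-c2ccnc(-c3ccc(N(C)C)cc3)c2)c1` is not yet measured. Its difference from compound 3 is:

hydrogen in place of methyl on an oxygen on an aromatic ring

Put otherwise, methoxy becomes hydroxy. Within the data shown here, no measured pair shows this change alone, so its size is open. The step from compound 3 to compound 4 is expected to be small, a number 5 percentage points lower from compound 3 to compound 4 (within the scatter), with no change beyond the scatter. Compound 4 is estimated at 83%, in the range 68% to 96%.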

Compound 4, a percentage reported as activity, at one concentration (the size of the read-out at that concentration, not a potency): 80%
Compound 4: the middle estimate sits 3 percentage points above what was measured; the measured number falls inside the stated range.
By their numbers in this assay, from the lowest: compounds 1, 2, 4 and 3 (each within the scatter of the next, the first and the last beyond it).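

In this assay, methoxy to hydroxy on the 3-methoxy-5-methylphenyl ring now has a single-change reading, a number 8 percentage points lower from compound 3 to compound 4 (within the scatter) and so no separation between the two compounds. With hydroxy held constant, dimethylamino in place of phenoxy on an aromatic carbon reads a number 2 percentage points higher from compound 2 to compound 4 (within the scatter) and also gives no separation. Nothing available explains the size of either step.

From the compounds shown here alone, whether an ethoxy group or an amine on that ring position would separate from hydroxy and methoxy remains open. So does the effect of a carboxylic acid in place of dimethylamino.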